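A few compounds are considered here, and "the series" means these few. Any claim that something is new, unique, unknown or untested is made for them only; others in the source may bear on it.

Compound 2 `COc1cccc(CNCCCNc2ccnc3cc(Cc4cc(C)cc(C)c4)ccc23)c1O` is the starting point of this step. In a physicochemical assay for solubility, with a stated time of 18 h, at pH 7.4 (on this read-out lower numbers stand for lower solubility and higher numbers for higher solubility), compound 2 gives 4200 nM. Its nearest measured neighbour is compound 1 `Cc1cc(C)cc(Cc2ccc3c(NCCCNCc4ccco4)ccnc3c2)c1`, which in this assay gives 4200 nM. Among the compounds with values here, the only step measured so far is no change at the digits printed from compound 1 to compound 2 (within the scatter), and it concerned a group on a saturated chain carbon bound to an amine nitrogen, with 2-hydroxy-3-methoxyphenyl in place of furan-2-yl. Compound 2 thus stands level with compound 1, within the usual scatter.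

Compound 3 `COc1cccc(CNCCCNc2ccnc3cc(Oc4cccc(N(C)C)c4)ccc23)c1O` differs from compound 2 at another place: 3-(dimethylamino)phenoxy in place of 3,5-dimethylbenzyl on an aromatic carbon. Within the data shown here, no measured pair covers a change at this aromatic carbon of the shared core, so the one step on record, no change at the digits printed from compound 1 to compound 2 (within the scatter), bears on it only in showing that one exchange of a side group left this assay unmoved. On that basis the expected step for compound 3 is a 1.2-fold higher number from compound 2 to compound 3 (0.08 log units; within the scatter), which lies within the scatter. The estimate for compound 3 in this assay is 5000 nM, with a range from 1500 nM to 16000 nM.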

Compound 3, solubility: 14500 nM
Compound 3: middle estimate off by 2.9-fold (0.46 log units), on the low side; low and high end bracket the measured number.
By their numbers in this assay, from the lowest: compounds 1 and 2 (each within the scatter of the next); then compound 3.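

At this aromatic carbon of the shared core, 3-(dimethylamino)phenoxy in place of 3,5-dimethylbenzyl gives in this assay a 3.5-fold higher number from compound 2 to compound 3 (0.54 log units; beyond the scatter) and so carries the read-out beyond the scatter, which the earlier exchange on the saturated chain carbon bound to an amine nitrogen did not do, with no change at the digits printed from compound 1 to compound 2 (within the scatter) on record there. The step is a single exchange of whole groups: the entering group brings one nitrogen and one oxygen and counts 2 hydrogen-bond acceptors, while the leaving group holds carbon only and counts 0, so the atom joining the aromatic ring to the core and the substituents on that ring change together and the step cannot be divided among them. Nothing measured here accounts for the higher number.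

The compounds shown leave open whether the dimethylamino group or the oxygen link carries the step, and how an unsubstituted phenoxy, a morpholine or a carboxylic acid at this aromatic carbon would read. They also leave open whether the same exchange gives a similar step with furan-2-yl on the chain, the group that compound 1 carries.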